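This account rests on a few compounds, and the source may have more. Where it says the series, first, only, none or still open, it means among the compounds named here.

In a functional assay on HeLa cells (Homo sapiens) for inhibition, read by CCK-8 assay, with a stated time of 48 h (on this read-out higher numbers stand for weaker inhibition and lower numbers for stronger inhibition), compound 2 `O=S(=O)(NCCNC(=S)Nc1cccc(Cl)c1)c1ccc(-c2ccccc2OCc2ccccc2)s1` gives 8400 nM, within the scatter of both measured neighbours. Compound 1 `O=S(=O)(NCCNC(=S)Nc1cccc(Cl)c1)c1ccc(-c2ccccc2OCc2cccc(O)c2)s1` gives 10700 nM, and compound 3 `O=[N+]([O-])c1ccc(NC(=S)NCCNS(=O)(=O)c2ccc(-c3ccccc3OCc3ccccc3)s2)cc1` gives 7100 nM. Compound 4 `O=[N+]([O-])c1ccc(Oc2ccccc2-c2ccc(S(=O)(=O)NCCNC(=S)Nc3cccc(Cl)c3)s2)cc1` has 4-nitrophenyl in place of benzyl on an oxygen on an aromatic ring. Within the data shown here, two measured steps bear on this only in part. The step of a 1.3-fold lower number from compound 1 to compound 2 (0.11 log units; within the scatter) concerns hydrogen in place of hydroxy on an aromatic carbon, while a 1.2-fold lower number from compound 2 to compound 3 (0.07 log units; within the scatter) brings in 4-nitrophenyl at a different place. Both stay within the scatter, and neither makes this exact change, so no shift beyond the scatter is expected. The step expected in this assay is a 1.2-fold lower number from compound 2 to compound 4 (0.08 log units; within the scatter). For compound 4 the estimated value is 7000 nM, with an expected range of 2800 nM to 17000 nM.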

Compound 4, half-maximal inhibitory concentration: 4600 nM
Beside the measured number, compound 4's estimate is 1.5-fold (0.18 log units) above it, within the range that was stated.
By their numbers in this assay, from the lowest: compounds 4, 3, 2 and 1 (each within the scatter of the next, the first and the last beyond it).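

On the oxygen on an aromatic ring, 4-nitrophenyl in place of benzyl gives a 1.8-fold lower number from compound 2 to compound 4 (0.26 log units; within the scatter) in this assay and so does not separate the pair. 4-Nitrophenyl in place of 3-hydroxybenzyl gives a 2.3-fold lower number from compound 1 to compound 4 (0.37 log units; beyond the scatter) in the same test. This is the only step shown that clears the scatter, and it does so modestly, so this position can shift the number a little. On these data alone, whether an amine or a carboxylic acid on this ring, or a longer chain on that oxygen, would shift it further stays open. Nothing available gives a cause for this shift.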